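The compounds below may be only part of what the source reports. "The series", "measured", "known", "first", "only" and "open" are said of these compounds alone.

In an ADME assay on HEK293 cells (Homo sapiens) for cytotoxicity, read by resazurin assay, with a stated time of 48 h (on this read-out higher numbers stand for lower toxicity in this test and lower numbers for higher toxicity in this test), compound 2 `Cc1ccc(S(=O)(=O)Nc2ccc3oc(-c4ccccc4)nc3c2)cc1` gives 75000 nM and compound 1 `Cc1ccc(S(=O)(=O)Nc2ccc(-c3nc4ccccc4o3)cc2)cc1` gives 88000 nM, two values within the scatter of each other. Compound 3 `O=S(=O)(Nc1ccc(-c2nc3ccccc3o2)cc1)c1ccc(Cl)s1` gives > 100000 nM, which is a limit and not a number. Compound 4 `O=S(=O)(Nc1ccc2oc(-c3ccccc3)nc2c1)c1cccc(F)c1` departs from compound 2 at one place: 3-fluorophenyl in place of 4-methylphenyl on a sulfonyl sulfur. Going by the values given here, the only measured step at this sulfonyl sulfur also removes 4-methylphenyl: an at least 1.1-fold higher number from compound 1 to compound 3 (0.05 log units; that floor lies within the scatter). That step rests on (the limit of > 100000 nM in this assay, at which 1 of the 3 values shown sits). With no measured step beyond the scatter to draw on, none is expected in this assay here. The estimated change is a 1.1-fold higher number from compound 2 to compound 4 (0.03 log units; within the scatter). For compound 4 the expected value is 80000 nM, with an estimated range from 45000 nM to 100000 nM.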

Compound 4, half-maximal cytotoxic concentration: 68000 nM
The estimate for compound 4 lay 1.2-fold (0.07 log units) above the measured number; low and high end bracket the measured number.
By their numbers in this assay, from the lowest: compounds 4, 2 and 1 (each within the scatter of the next). At a limit, above all of these: compound 3.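

At this sulfonyl sulfur, a change of aryl group now has a number on both sides: in this assay the step is a 1.1-fold lower number from compound 2 to compound 4 (0.04 log units; within the scatter). On the core of compound 2, 3-fluorophenyl in place of 4-methylphenyl therefore leaves the read-out within the scatter. The step on the core of compound 1 gives only a floor, as compound 3 stands at a limit: the limit of > 100000 nM in this assay, at which 1 of the 4 values shown sits.

On these data alone, whether an amine or a longer alkyl chain on this sulfur would move the number beyond the scatter stays open. Also open, as far as these compounds go, is what 5-chlorothiophen-2-yl does on the core of compound 2.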